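The source may report more compounds than this note shows. Statements on the series, on what has been measured and on what is new or still open speak of the compounds shown alone.

Of the compounds shown here, three built on one shared core have been measured in an assay on isolated protein (Cavia porcellus) with Sigma non-opioid intracellular receptor 1 (Homo sapiens) as the target, read by radioligand binding; a lower number here means a stronger inhibitor, a higher number a weaker inhibitor. Compound 1 `CN(C)CCCCOc1ccc2oc(-c3ccccc3)cc(=O)c2c1` gives 400 nM and stands highest of the three numbers. Compound 2 `CN(C)CCCCCCCCCCOc1ccc2oc(-c3ccccc3)cc(=O)c2c1` gives 341 nM, and compound 3 `O=c1cc(-c2ccccc2)oc2ccc(OCCCCCCN3CCC(O)CC3)cc12` gives 121 nM.

The step from compound 1 to compound 2 shows a 1.2-fold lower number from compound 1 to compound 2 (0.07 log units; within the scatter), so the longer chain on its own leaves the number where it was. The step to compound 3 shows a 3.3-fold lower number from compound 1 to compound 3 (0.52 log units; beyond the scatter), a modest gain that comes with the 4-hydroxypiperidin-1-yl ring; the same is seen in a 2.8-fold lower number from compound 2 to compound 3 (0.45 log units; beyond the scatter).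

Compound 4 `O=c1cc(-c2ccccc2)oc2ccc(OCCCCCCN3CCCC(O)C3)cc12` is not yet measured. It differs from compound 1 in one place: 2-(3-hydroxypiperidin-1-yl)ethyl in place of dimethylamino on a saturated chain carbon, four bonds along the chain from an oxygen on an aromatic ring. Going by the values given here, this is the same kind of change as the one leading to compound 3, with a 3-hydroxypiperidin-1-yl ring in place of the 4-hydroxypiperidin-1-yl ring. Because a 3.3-fold lower number from compound 1 to compound 3 (0.52 log units; beyond the scatter) was modest and beyond the scatter, a step of similar size and direction is expected, estimated as a 2.7-fold lower number from compound 1 to compound 4 (0.43 log units; beyond the scatter). For compound 4 the expected value in this assay is 150 nM, with a range from 60 nM to 400 nM.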

Compound 4, half-maximal inhibitory concentration: 77 nM
For compound 4 the middle estimate is 1.9-fold (0.29 log units) above the measured one; measured number inside the range.
By their numbers in this assay, from the lowest: compounds 4 and 3 (each within the scatter of the next); then compounds 2 and 1 (each within the scatter of the next).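

In this assay, 3-hydroxypiperidin-1-yl in place of 4-hydroxypiperidin-1-yl gives a 1.6-fold lower number from compound 3 to compound 4 (0.20 log units; within the scatter), so at the end of this chain the two hydroxypiperidine rings cannot be told apart. The advantage over the dimethylamino compounds is therefore not tied to a single ring: it appears again as a 5.2-fold lower number from compound 1 to compound 4 (0.72 log units; beyond the scatter) and as a 4.4-fold lower number from compound 2 to compound 4 (0.65 log units; beyond the scatter), both larger than the scatter. Nothing available explains why these rings give lower numbers than dimethylamino.

The compounds shown leave open whether the ring itself or its hydroxyl goes with the lower numbers, a question that a plain piperidin-1-yl ring with no hydroxyl would help to settle. They also leave open whether either hydroxypiperidine ring would give a similar step on the shorter chain of compound 1.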